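Replacing 4-bromophenyl with 3-methoxyphenyl in compound 2

The source may report more compounds than this note shows. Statements on the series, on what has been measured and on what is new or still open speak of the compounds shown alone.

Compound 1 `COc1ccc(/C=C2\CCC/C(=C\c3cccc(OC)c3OC)C2=O)cc1OC` – 14900 nM
Compound 2 `COc1ccc(/C=C2\CCC/C(=C\c3ccc(Br)cc3)C2=O)cc1OC` – 13100 nM

In an ADME assay on NHDF cells (Homo sapiens) for cytotoxicity, read by MTT assay, with a stated time of 72 h (on this read-out higher numbers stand for weaker inhibition and lower numbers for stronger inhibition), compound 2 at 13100 nM lies within the usual scatter of compound 1 at 14900 nM so the two cannot be told apart. Compound 3 `COc1cccc(/C=C2\CCC/C(=C\c3ccc(OC)c(OC)c3)C2=O)c1` differs from compound 2 in one place, with 3-methoxyphenyl in place of 4-bromophenyl on a double-bonded chain carbon bound to a double-bonded ring carbon. Among the measured compounds shown here, no two measured compounds differ in just one place, so no measured step can guide the size of this one. Compound 1 has no bromine and still gives 14900 nM which is close to the value of compound 2, so in this assay no change beyond the scatter is expected. The expected step is a 1.1-fold higher number from compound 2 to compound 3 (0.03 log units; within the scatter) and it should stay within the scatter. For compound 3 the estimate is 14000 nM with an expected range from 6500 nM to 30000 nM in this measurement.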

Compound 3, half-maximal inhibitory concentration: 11600 nM
Compound 3: middle estimate off by 1.2-fold (0.08 log units), on the high side; the range from low to high includes it.
By their numbers in this assay, from the lowest: compounds 3, 2 and 1 (each within the scatter of the next).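

In this assay, 3-methoxyphenyl in place of 4-bromophenyl on a double-bonded chain carbon bound to a double-bonded ring carbon gives a 1.1-fold lower number from compound 2 to compound 3 (0.05 log units; within the scatter), so a ring carrying bromine and one carrying methoxy cannot be told apart at this position. Among the compounds shown here, the earlier compounds differed in more than one place, whereas these are the first single changes that can be read directly. Hydrogen in place of methoxy on an aromatic carbon gives a 1.3-fold lower number from compound 1 to compound 3 (0.11 log units; within the scatter), so removing that one methoxy also leaves the compounds indistinguishable.

On these data alone, whether an amine or a carboxylic acid on this ring would move the number beyond the scatter stays open. Nothing given here offers a reason why these changes make no visible difference.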